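This account rests on a few compounds, and the source may have more. Where it says the series, first, only, none or still open, it means among the compounds named here.

Compound 1 `Cc1c(OCCCCOc2ccc(C(=O)O)cc2Cl)ccc(C(=O)CC(C)C)c1O`: 62.9%
Compound 2 `Cc1c(OCCCCOc2ccc(F)c(C(=O)O)c2)ccc(C(=O)CC(C)C)c1C`: 13.8%
Compound 3 `Cc1c(OCCCCOc2ccc(F)c(C(=O)O)c2)ccc(C(=O)CC2CCCC2)c1C`: 12.6%

All three were measured in an assay on HEK293 cells for positive allosteric modulation of metabotropic glutamate receptor 3 (Rattus norvegicus), read by thallium flux, with a stated time of 2.5 min; on this read-out higher numbers stand for larger maximal responses and lower numbers for smaller maximal responses. Compound 2 stands second highest of the three: the nearest value, a number 1.2 percentage points lower from compound 2 to compound 3 (within the scatter), lies within the scatter, while compound 1 lies far above, beyond the scatter. Compound 4 `Cc1c(OCCCCOc2ccc(F)c(C(=O)O)c2)ccc(C(=O)CC(C)C)c1O` has not been measured yet. It differs from compound 2 in one place: hydroxy in place of methyl on an aromatic carbon. Among the measured compounds shown here, no measured step changes this place alone. For the measured compounds named here, the only measured step, a number 1.2 percentage points lower from compound 2 to compound 3 (within the scatter), concerns a different place and shows almost nothing. Compound 4 does carry the same hydroxy group as compound 1, whose value of 62.9% is much higher, though compound 1 also differs from compound 2 in a second place, so this hint is loose. Compound 4 is expected to give 38%, with a likely range from 14% to 65%. The expected step, a number 24.2 percentage points higher from compound 2 to compound 4 (beyond the scatter), would be an upward one beyond the scatter.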

Compound 4, largest response reached (reported as percent of maximum), in percent of the reference or control that the assay uses: 81.7%
Compound 4: middle estimate off by 43.7 percentage points, on the low side, and the stated range ends below it.
By their numbers in this assay, from the lowest: compounds 3 and 2 (each within the scatter of the next); then compound 1; then compound 4.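

In this assay, hydroxy in place of methyl on this aromatic carbon is a large change on its own: a number 67.9 percentage points higher from compound 2 to compound 4 (beyond the scatter). With the hydroxy present in both compounds, 3-carboxy-4-fluorophenyl in place of 4-carboxy-2-chlorophenyl is a modest change by comparison: a number 18.8 percentage points higher from compound 1 to compound 4 (beyond the scatter). Nothing available here explains why the hydroxy has so large an effect. Still open, from the compounds shown here alone, is whether a methoxy group, an amine or a fluorine on this carbon would also give a high response. Also open, going by these compounds, is whether the hydroxy would raise the response in the same way alongside the cyclopentyl group of compound 3.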